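A few compounds are considered here, and "the series" means these few. Any claim that something is new, unique, unknown or untested is made for them only; others in the source may bear on it.

In an in vitro ADME assay on microsomes from liver (Homo sapiens) for pharmacokinetics, read by LC-MS, with a stated time of 10 min, tested at 1 uM (on this read-out lower numbers stand for slow clearance and higher numbers for fast clearance), compound 1 (`CN1C[C@H](C(=O)Nc2ccc(C#N)cc2)[C@@H](c2ccc(/C=C/C(=O)Nc3ccccc3N)cc2)C1`) reads 1 mL/min/kg and compound 2 (`CN1C[C@H](C(=O)Nc2ccc(C3CC3)cc2)[C@@H](c2ccc(/C=C/C(=O)Nc3ccccc3N)cc2)C1`) reads 12 mL/min/kg while compound 3 (`CN1C[C@H](C(=O)Nc2ccc(Br)cc2)[C@@H](c2ccc(/C=C/C(=O)Nc3ccccc3N)cc2)C1`) reads 3 mL/min/kg and so sits in the middle of the three. Still unmeasured is compound 4 (`CN1C[C@H](C(=O)Nc2cccc(F)c2)[C@@H](c2ccc(/C=C/C(=O)Nc3ccccc3N)cc2)C1`), where 3-fluorophenyl takes the place of 4-bromophenyl on an amide-type nitrogen (3-fluorophenyl in place of 4-bromophenyl on an amide-type nitrogen). The closest evidence comes from changes on that same aromatic group. Bromo in place of cyano gave a 3.0-fold higher number from compound 1 to compound 3 (0.48 log units; beyond the scatter) and bromo in place of cyclopropyl gave a 4.0-fold lower number from compound 2 to compound 3 (0.60 log units; beyond the scatter) while cyclopropyl in place of cyano gave a 12-fold higher number from compound 1 to compound 2 (1.08 log units; beyond the scatter) as the largest step. All three lie beyond the usual scatter, so this group can clearly shift the number. Within the data shown here, none of them, however, swaps bromo for fluoro, so no measured step speaks directly to this change. With no direction favoured, the expected step is no change at the digits printed from compound 3 to compound 4 (within the scatter) and it is not expected to exceed the scatter. For compound 4 the estimated clearance is 3 mL/min/kg with an expected range from 1 mL/min/kg to 10 mL/min/kg in this measurement.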

Compound 4, clearance: 6 mL/min/kg
Beside the measured number, compound 4's estimate is 2.0-fold (0.30 log units) below it; the range from low to high includes it.
By their numbers in this assay, from the lowest: compound 1; then compounds 3, 4 and 2 (each within the scatter of the next, the first and the last beyond it).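

In this assay, among these compounds, the first change at this amide-type nitrogen to alter both the halogen and its printed ring position gives a 2.0-fold higher number from compound 3 to compound 4 (0.30 log units; within the scatter), so this swap cannot be told apart from repeat-measurement noise. The other two comparisons give a 2.0-fold lower number from compound 2 to compound 4 (0.30 log units; within the scatter) and a 6.0-fold higher number from compound 1 to compound 4 (0.78 log units; beyond the scatter): compound 4 falls within the scatter of compounds 2 and 3, even though those two lie beyond the scatter of each other, while 4-cyanophenyl in compound 1 remains clearly apart from all three other groups. No measurement shown bears on the reason for these differences.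

Compound 4 alters the halogen and its ring position together, and these two changes cannot be separated here. As far as these compounds go, it also remains open how this clearance would respond to a phenyl group carrying an amine or a carboxylic acid.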